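Bringing an Amide Back on a Pyridine Ring

The compounds below may be only part of what the source reports. "The series", "measured", "known", "first", "only" and "open" are said of these compounds alone.

Two compounds share a core, and differ only in the aromatic group attached to it. Compound 1 `NC(=O)c1cccc(-c2cnc(C(=O)CCCCCCc3ccccc3)o2)c1` carries a 3-carbamoylphenyl group, and in an assay (Rattus norvegicus) for inhibition of Fatty-acid amide hydrolase 1 (Homo sapiens) (a higher number here means a weaker inhibitor, a lower number a stronger inhibitor), compound 1 gives 6 nM. Going by the values given here, compound 2 `N#Cc1ccc(-c2cnc(C(=O)CCCCCCc3ccccc3)o2)cc1` carries a 4-cyanophenyl group instead, and in this assay compound 2 gives 40 nM, the higher of the two numbers known, so it is the weaker inhibitor of the pair. Among the compounds with values here, the only measured step, a 6.7-fold higher number from compound 1 to compound 2 (0.82 log units; beyond the scatter), shows that trading the amide-bearing ring for the nitrile-bearing ring cost potency. Compound 3 `NC(=O)c1ccc(-c2cnc(C(=O)CCCCCCc3ccccc3)o2)nc1` moves in the opposite direction: 5-carbamoylpyridin-2-yl in place of 4-cyanophenyl on an aromatic carbon. The carbamoyl group returns, now on a pyridin-2-yl ring, and the nitrile is gone. Because compound 1 with its carbamoyl group gave 6 nM, compound 3 is expected to show a step of about a 5.0-fold lower number from compound 2 to compound 3 (0.70 log units; beyond the scatter). Compound 3 is estimated at 8 nM, with a likely range from 3 nM to 25 nM.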

Compound 3, inhibition constant: 1.2 nM
Compound 3: the middle estimate sits 6.7-fold (0.82 log units) above what was measured; the whole stated range lies above it.
By their numbers in this assay, from the lowest: compound 3; then compound 1; then compound 2.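

Putting 5-carbamoylpyridin-2-yl in place of 4-cyanophenyl on this aromatic carbon, next to the ring oxygen, gives a 33-fold lower number from compound 2 to compound 3 (1.52 log units; beyond the scatter), a larger step than the one seen earlier at this position. The carbamoyl group is not the whole story: compounds 1 and 3 both carry one, yet 5-carbamoylpyridin-2-yl in place of 3-carbamoylphenyl still gives a 5.0-fold lower number from compound 1 to compound 3 (0.70 log units; beyond the scatter), so the group attached here matters beyond the presence of that amide. No measurement here explains why either step occurs.

The compounds shown do not separate the effect of the ring nitrogen from that of where the carbamoyl group sits on the ring. Going by these compounds, whether a carboxylic acid or an amine could replace the carbamoyl group on the pyridin-2-yl ring and keep this potency also remains open.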